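Chloro-to-fluoro swap on a chalcone-pyrazole growth inhibitor

The source may hold more compounds than are shown below. What is called first, only, known or untested is meant among the compounds shown, and "the series" means these compounds.

Measured compounds:
compound 1, `COc1ccc(-c2cc(/C=C/C(=O)c3ccc(N)cc3)[nH]n2)cc1`, 15400 nM
compound 2, `COc1cc(-c2cc(/C=C/C(=O)c3ccc(Cl)c(Cl)c3)[nH]n2)cc(OC)c1OC`, 34000 nM

In a functional assay on OVCAR-8 cells (Homo sapiens) for inhibition, read by sulforhodamine B assay, with a stated time of 48 h (a higher number here means a weaker inhibitor of growth, a lower number a stronger inhibitor of growth), compound 2 gives 34000 nM, the higher of the two numbers recorded; compound 1 gives 15400 nM in this assay, a gap between the two that lies beyond the usual scatter. Compound 2 therefore stands as the weaker growth inhibitor of the pair.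

Compound 3, `COc1cc(-c2cc(/C=C/C(=O)c3ccc(F)c(F)c3)[nH]n2)cc(OC)c1OC`, keeps the core of compound 2 and differs only at one place: 3,4-difluorophenyl in place of 3,4-dichlorophenyl on a carbonyl carbon. Going by the values given here, no pair of measured compounds shows the effect of such a change in this assay, so the expectation rests on compound 2 alone. The step from compound 2 to compound 3 is expected to be small, either none beyond the scatter or a modest move toward a higher number, a 1.2-fold higher number from compound 2 to compound 3 (0.07 log units; within the scatter).

Compound 3 is thus estimated at 40000 nM in this assay, with a range from 13000 nM to 120000 nM.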

Compound 3, concentration for total growth inhibition: 17300 nM
The estimate for compound 3 lay 2.3-fold (0.36 log units) above the measured number; the measured number falls inside the stated range.
By their numbers in this assay, from the lowest: compounds 1, 3 and 2 (each within the scatter of the next, the first and the last beyond it).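

In this assay, going by these compounds alone, 3,4-difluorophenyl in place of 3,4-dichlorophenyl on a carbonyl carbon gives a 2.0-fold lower number from compound 2 to compound 3 (0.29 log units; within the scatter) and so offers the first reading of a single change at this position, since compound 1 and compound 2 differ in more than one place. The step does not separate the two halogen pairs, and on the core of compound 2 this assay gives no ground for ranking one above the other. Nothing measured here speaks to what lies behind this result.

On these data alone, it remains open whether a group of another kind on the same carbonyl carbon, such as a 4-carboxyphenyl or 4-cyanophenyl ring, would give a step beyond the scatter. As far as these compounds go, it is also open whether the same swap would read the same way on a core carrying a different set of methoxy groups.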